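Aryl swap on the shared core: compound 2 to compound 3

A few compounds are considered here, and "the series" means these few. Any claim that something is new, unique, unknown or untested is made for them only; others in the source may bear on it.

Measured so far:
compound 1, `O=C(/C(=C/c1ccccc1)CCl)c1ccccc1`: 12000 nM
compound 2, `C=C(C/C(=C\c1ccc(Cl)cc1)C(=O)c1ccccc1)C(=O)c1ccccc1`: 17000 nM

In a functional assay on HBL-100 cells (Homo sapiens) for inhibition, read by sulforhodamine B assay, with a stated time of 48 h (on this read-out higher numbers stand for weaker inhibition of growth and lower numbers for stronger inhibition of growth), compound 1 gives 12000 nM. In the same assay compound 2 gives 17000 nM. Compound 2 carries the highest of the two numbers shown; its nearest neighbour is compound 1, and the gap between them lies within the scatter of repeated measurements, so the two values are not distinguishable on this read-out. Going by the values given here, no pair of measured compounds differs in one place only, so no single-point step is available to calibrate the change below.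

Compound 3, `C=C(C/C(=C\c1ccccc1F)C(=O)c1ccccc1)C(=O)c1ccccc1`, differs from compound 2 by 2-fluorophenyl in place of 4-chlorophenyl on a double-bonded chain carbon bound to a double-bonded chain carbon. Among the compounds with values here, nothing among the measured compounds reports how such an aryl swap moves this assay. With the two measured values sitting within the scatter of one another, the working expectation is that this change produces no step beyond the scatter, in either direction. The step from compound 2 to compound 3 is therefore expected to be a 1.1-fold lower number from compound 2 to compound 3 (0.05 log units; within the scatter). For compound 3 the expected value in this assay is 15000 nM, with a range from 6000 nM to 40000 nM.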

Compound 3, concentration for 50% growth inhibition: 15000 nM
The estimate for compound 3 equals the measured number at the digits printed, and the stated range covers the measured number.
By their numbers in this assay, from the lowest: compounds 1, 3 and 2 (each within the scatter of the next).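

In this assay, going by these compounds alone, 2-fluorophenyl in place of 4-chlorophenyl on a double-bonded chain carbon bound to a double-bonded chain carbon gives a 1.1-fold lower number from compound 2 to compound 3 (0.05 log units; within the scatter) and supplies the only single-place comparison so far. The earlier compounds shown here could not speak to this position, whereas this pair shows that these two halogen-bearing phenyl groups are not distinguishable there on this read-out, although the halogen and its place on the ring both differ. No evidence on the reason for this outcome is available.

Because the swap alters the halogen and its ring place together, the pair cannot separate the two, and 2-chlorophenyl or 4-fluorophenyl would be needed to do so. On these data alone, it also remains open whether this position stays as flat for groups further from these two, such as a phenyl ring carrying an amine or a carboxylic acid, or a longer alkyl chain in place of the ring.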